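Aryl for Benzyl on the Amine of Compound 2

This account rests on a few compounds, and the source may have more. Where it says the series, first, only, none or still open, it means among the compounds named here.

Measured compounds:
compound 1, `OCCCCNCc1nc2c(OCC3CCCCC3)cccc2[nH]1`: 44.3%
compound 2, `c1ccc(CNCc2nc3c(OCC4CCCCC4)cccc3[nH]2)cc1`: 49.3%

In an assay on cells for inhibition of interleukin-5 receptor subunit alpha (Mus musculus), read by WST assay, with a stated time of 48 h, tested at 30 uM, in the presence of a further agent that is not named here (a higher number here means more inhibition at the concentration tested (going by the name of the read-out), a lower number less inhibition), compound 1 gives 44.3% and compound 2 gives 49.3%. Going by the values given here, compound 2 carries the higher of the two numbers, yet the only measured step, a number 5 percentage points higher from compound 1 to compound 2 (within the scatter), lies within the scatter, so the two compounds stand level on what is known.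

Compound 3, `COc1ccc(NCc2nc3c(OCC4CCCCC4)cccc3[nH]2)cc1`, has not yet been measured. It differs from compound 2 in one place: 4-methoxyphenyl in place of benzyl on an amine nitrogen. Among the compounds with values here, no measured step changes the group on the amine nitrogen itself; the single step known exchanged phenyl for 3-hydroxypropyl on a saturated chain carbon bound to an amine nitrogen and moved nothing beyond the scatter. Within the data shown here, with that as the only guide, no step beyond the scatter is expected in this assay for compound 3, and a number 1.3 percentage points lower from compound 2 to compound 3 (within the scatter) is the expected change. Compound 3 is therefore estimated at 48%, within 30% to 66%.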

Compound 3, a percentage reported as inhibition, at one concentration (the size of the read-out at that concentration, not a potency): 20.3%
Compound 3: the middle estimate sits 27.7 percentage points above what was measured; the measured number lies below the stated range.
By their numbers in this assay, from the lowest: compound 3; then compounds 1 and 2 (each within the scatter of the next).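

In this assay, the change to 4-methoxyphenyl on the amine nitrogen gives a number 29 percentage points lower from compound 2 to compound 3 (beyond the scatter), and the same group in place of 4-hydroxybutyl gives a number 24 percentage points lower from compound 1 to compound 3 (beyond the scatter). The earlier compounds shown here, with benzyl and 4-hydroxybutyl on this nitrogen, stood level, so this position had seemed to accept quite different groups; compound 3 shows that it does not accept every group equally. Nothing available bears on what lies behind the lower number.

The compounds shown do not separate the methoxy group from the aromatic ring standing directly on the nitrogen, and a plain phenyl there would divide the two. They also leave open whether a 4-methoxybenzyl group, which keeps the chain carbon of benzyl and adds the methoxy group, stays level with compound 2.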